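The source may report more compounds than this note shows. Statements on the series, on what has been measured and on what is new or still open speak of the compounds shown alone.

Working notes on the series. Three members have been measured: compound 1 `Cc1ccc2c(=O)c(CSC(=S)N3CCCCC3)coc2c1`, compound 2 `O=c1c(CSC(=S)N2CCOCC2)coc2cc(Cl)ccc12` and compound 3 `O=c1c(CSC(=S)N2CCOCC2)coc2ccccc12`, all in a functional assay on HEp-2 cells (Homo sapiens) for antiproliferative activity, read by MTT assay, with a stated time of 72 h; a lower number here means a stronger inhibitor, a higher number a weaker inhibitor. In this assay compound 1 gives 900 nM and compound 2 gives 900 nM. Compound 3 gives 4400 nM, the highest of the three numbers, with compound 1 and compound 2 standing an equal distance below it. Among the compounds with values here, compound 2 and compound 3 differ in one place only, and the step of a 4.9-fold higher number from compound 2 to compound 3 (0.69 log units; beyond the scatter) is the single one-place comparison the set provides. Compound 1 differs from compound 3 in two places, the methyl and the cyclic amine, so its value can only be set beside that of compound 3 without being split into parts.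

Compound 4 `Cc1ccc2c(=O)c(CSC(=S)N3CCOCC3)coc2c1` is not yet measured. It differs from compound 3 by methyl in place of hydrogen on an aromatic carbon. The bearing step is that from compound 2 to compound 3, where loss of a substituent from the aromatic ring raised the number by a modest amount beyond the scatter; compound 1, which carries the same methyl as compound 4 though with a different amine, sits at the lower value. A step in the opposite sense to a 4.9-fold higher number from compound 2 to compound 3 (0.69 log units; beyond the scatter) is therefore expected for compound 4, though methyl is not chloro, so a smaller one is estimated: a 3.4-fold lower number from compound 3 to compound 4 (0.53 log units; beyond the scatter). Compound 4 is accordingly expected to give about 1300 nM in this assay, with a likely range of 500 nM to 3500 nM.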

Compound 4, half-maximal inhibitory concentration: 4000 nM
The estimate for compound 4 lay 3.1-fold (0.49 log units) below the measured number; the measured number lies above the stated range.
By their numbers in this assay, from the lowest: compounds 1 and 2 (each within the scatter of the next); then compounds 4 and 3 (each within the scatter of the next).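

At this aromatic carbon, methyl cannot be told apart from hydrogen in this assay (a 1.1-fold lower number from compound 3 to compound 4 (0.04 log units; within the scatter)), so the lower number that chloro brought to compound 2 does not carry over to every group placed there. Within the data shown here, with the morpholin-4-yl group held constant, the identity of the group at this carbon still matters, since methyl and chloro stand clearly apart (a 4.4-fold higher number from compound 2 to compound 4 (0.65 log units; beyond the scatter)), and with methyl held constant the amine on the thiocarbonyl carbon has a step of its own (a 4.4-fold higher number from compound 1 to compound 4 (0.65 log units; beyond the scatter)), which the earlier compounds could not separate from the ring substituent. No measurement in hand accounts for either step.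

The compounds shown leave open whether the step from morpholin-4-yl to piperidin-1-yl has the same size when the aromatic carbon carries chloro or hydrogen, as the amine has been varied only with methyl there. They also leave open whether fluoro, bromo, methoxy or trifluoromethyl at this carbon would sit with chloro or with methyl and hydrogen, and how an open-chain amine such as diethylamine would compare on the thiocarbonyl carbon.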